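Isopropyl on the thioether ring of a quinoline lactone

The source may report more compounds than this note shows. Statements on the series, on what has been measured and on what is new or still open speak of the compounds shown alone.

Of the compounds shown here, two that share a lactone-bearing quinoline core have been measured in an assay (strain Holtzman-Sprague-Dawley) for inhibition of 3-hydroxy-3-methylglutaryl-coenzyme A reductase (Rattus norvegicus), with a stated time of 30 min; on this read-out higher numbers stand for weaker inhibition and lower numbers for stronger inhibition. Compound 1 `COc1cccc(Sc2c(/C=C/[C@@H]3C[C@@H](O)CC(=O)O3)cnc3cc(Cl)c(F)cc23)c1` gives 9240 nM in this assay. Compound 2 `O=C1C[C@H](O)C[C@@H](/C=C/c2cnc3c(F)c(F)c(F)cc3c2Sc2ccccc2)O1` gives 10700 nM in this assay, the higher of the two numbers; the gap to compound 1 lies within the scatter, so the two cannot be ranked against each other. Compound 3 `CC(C)c1ccc(Sc2c(/C=C/[C@@H]3C[C@@H](O)CC(=O)O3)cnc3c(F)c(F)c(F)cc23)cc1` has not yet been measured; it differs from compound 2 by isopropyl in place of hydrogen on an aromatic carbon. Among the measured compounds shown here, no pair of measured compounds shows this change, so nothing here tells how large its effect will be. An isopropyl group entering on an aromatic carbon is a small addition, and the author expects a moderate step toward stronger inhibition, a 3.1-fold lower number from compound 2 to compound 3 (0.49 log units; beyond the scatter), possibly no more than the scatter. Compound 3 is therefore expected to give about 3500 nM in this assay, with a likely range from 1000 nM to 12000 nM.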

Compound 3, half-maximal inhibitory concentration: 3210 nM
Estimate against measurement, compound 3: 1.1-fold (0.04 log units) above; the range from low to high includes it.
By their numbers in this assay, from the lowest: compound 3; then compounds 1 and 2 (each within the scatter of the next).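

In this assay, isopropyl in place of hydrogen on an aromatic carbon, para to a large group, brings a 3.3-fold lower number from compound 2 to compound 3 (0.52 log units; beyond the scatter). Among the compounds shown here, this is the first single change that can be read, as the two earlier compounds differ in more than one place and could not show what this carbon tolerates. Turning phenylsulfanyl into (4-isopropylphenyl)sulfanyl does not cost inhibition here; the number falls by a modest step, and no measurement at hand accounts for it.

As far as these compounds go, whether the gain is particular to isopropyl stays open, since a single group at this carbon cannot show how a smaller methyl, a larger tert-butyl or an amine would fare. Also open, from the compounds shown here alone, is whether isopropyl gives a similar step on the core of compound 1.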